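Methyl to ethyl on compound 2

The source may hold more compounds than are shown below. What is called first, only, known or untested is meant among the compounds shown, and "the series" means these compounds.

Measured in a functional assay on the whole organism (Myocardium) with Canis familiaris (Canis lupus familiaris) as the target; on this read-out higher numbers stand for an effect only at larger amounts of compound and lower numbers for an effect already at smaller amounts:
- compound 1 `O=C1CC(c2ccc(-n3ccnc3)cc2)=NN1` gives > 1 mg/kg as a limit
- compound 2 `CC1C(=O)NN=C1c1ccc(-n2ccnc2)cc1` gives > 1 mg/kg as a limit

On these data alone, compound 2 stands at > 1 mg/kg as a limit and not a number, so its true place remains open. Compound 3 `CCC1C(=O)NN=C1c1ccc(-n2ccnc2)cc1` differs from compound 2 by methyl in place of hydrogen on a saturated chain carbon bound to a saturated ring carbon in the form of methyl in place of hydrogen on a saturated chain carbon bound to a saturated ring carbon, which also reads as methyl to ethyl. Going by the values given here, the only measured step of a like kind is a step that the two limits leave unreadable from compound 1 to compound 2 for methyl in place of hydrogen on a saturated ring carbon. That step offers no size and no direction to carry over, so no step beyond the scatter is expected in this assay on this evidence. For compound 3 the estimate is 2 mg/kg with an expected range from 0.6 mg/kg to 6 mg/kg and another limit is the likelier report. The estimated step is a step that the limit leaves unreadable from compound 2 to compound 3 and it remains a rough expectation.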

Compound 3, dose for half-maximal effect: > 1 mg/kg
Compound 3: no number, only a limit; the forecaster's own chance of this, stated with the estimate: 70%; the middle value is on the limit's open side.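

No new step can be read among compound 1, compound 2 and compound 3 in this assay, because all three stand only as limits: the limit of > 1 mg/kg in this assay, at which 3 of the 3 values shown sit.

The compounds shown leave open where each truly stands, and whether methyl or ethyl in place of hydrogen changes the read-out at all.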